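The compounds below may be only part of what the source reports. "The series", "measured", "known", "first", "only" and "open" are said of these compounds alone.

Compound 1, `O=C1C(Nc2ccccc2)=CC(=O)c2c1nc1n2[C@H]2OC[C@@H](O)[C@H]2OC1`, gives > 8000 nM in a functional assay on HeLa cells (Homo sapiens) for inhibition, read by sulforhodamine B assay (a lower number here means a stronger inhibitor, a higher number a weaker inhibitor), a limit of the assay rather than a number.
Compound 2, `O=C1C(NC2CCCC2)=CC(=O)c2c1nc1n2[C@H]2OC[C@@H](O)[C@H]2OC1`, gives > 16000 nM in this assay, again a limit.
Compound 3, `O=C1C=C(Nc2ccccc2F)C(=O)c2c1nc1n2[C@H]2OC[C@@H](O)[C@H]2OC1`, gives 5120 nM in this assay.

Going by the values given here, compound 3 thus holds the only measured number in this set; the two other values are limits, one at the limit of > 8000 nM in this assay, at which 1 of the 3 values shown sits, and one at the limit of > 16000 nM in this assay, at which 1 of the 3 values shown sits. Compound 4, `O=C1C=C(N2CCCC2)C(=O)c2c1nc1n2[C@H]2OC[C@@H](O)[C@H]2OC1`, has not yet been measured. It differs from compound 3 by pyrrolidin-1-yl in place of (2-fluorophenyl)amino on a double-bonded ring carbon.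

Among the compounds with values here, the one measured step, a step that the two limits leave unreadable from compound 1 to compound 2, also replaces an aromatic group on an amine nitrogen with a saturated ring, but both of its ends are limits, so its size and direction cannot be read. Within the data shown here, no measured step therefore speaks for or against a change beyond the scatter on going from compound 3 to compound 4, and the ring nitrogen of compound 4 carries no hydrogen-bond donor, unlike the amine of compound 3.

With this weak footing, compound 4 is expected to sit near or somewhat weaker than compound 3, an estimated step of a 2.0-fold higher number from compound 3 to compound 4 (0.29 log units; within the scatter). The estimate for compound 4 in this assay is 10000 nM, with a range from 3000 nM to 30000 nM.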

Compound 4, half-maximal inhibitory concentration: > 16000 nM
Compound 4: only a limit was reported; the forecaster's own chance of this, stated with the estimate: 50%; at least 1.6-fold (0.20 log units) between middle value and limit.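

Going by these compounds alone, until now, the only step in this assay ran between two limits and could not be read, so this pair gives the first readable comparison in the set. On the double-bonded ring carbon, pyrrolidin-1-yl in place of (2-fluorophenyl)amino gives an at least 3.1-fold higher number from compound 3 to compound 4 (0.49 log units; beyond the scatter), which shows that activity at this position does depend on the group it carries, and that here the change costs activity beyond the scatter. Compound 4 gives only a limit, so the step has a lower bound and its full size cannot be read: the limit of > 16000 nM in this assay, at which 2 of the 4 values shown sit.

The change removes the six-membered aromatic ring and the hydrogen-bond donor together, so the compounds shown do not tell which of the two loss accounts for the step, or whether both contribute. A methyl(2-fluorophenyl)amino group at this place would keep the aromatic ring without the amine hydrogen, and a cyclopentylamino group at this place would keep the amine hydrogen without the aromatic ring, so the two together could pull these features apart.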